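The compounds below may be only part of what the source reports. "The series", "measured", "known", "first", "only" and "open" are said of these compounds alone.

Compound 1 `CC1=C(O)[C@@H](C/C(C)=C\CC[C@H](C)/C=C/C=C(\C)CCCc2ccoc2)OC1=O` — 5.6 ug/mL
Compound 2 `CC1=C(O)[C@@H](C/C(C)=C\CC[C@H](C)/C=C/C=C(\C)CCCC2=CCN(CCC(C)C)C2=O)OC1=O` — 3.4 ug/mL

In a functional assay on SK-MEL-2 cells (Homo sapiens) for cytotoxicity (on this read-out higher numbers stand for an effect only at larger amounts of compound and lower numbers for an effect already at smaller amounts), compound 1 gives 5.6 ug/mL, the higher of the two numbers, with compound 2 nearest at 3.4 ug/mL; the step of a 1.6-fold lower number from compound 1 to compound 2 (0.22 log units; within the scatter) stays within the scatter. Compound 3 `COC(=O)C(O)C/C(C)=C\CC[C@H](C)/C=C/C=C(\C)CCCc1ccoc1` differs from compound 1 by a group of 6 heavy atoms (3 carbon, 3 oxygen; no ring) in place of a group of 8 heavy atoms (5 carbon, 3 oxygen; one five-membered non-aromatic ring with 1 hetero atom), on a saturated chain carbon bound to a double-bonded chain carbon. For the measured compounds named here, the only measured step alters the other end of the chain and does not touch the group that leaves here, so no measured step bears on this change. Compound 3 is therefore estimated near compound 1, with a wide range: 8 ug/mL (3 ug/mL to 25 ug/mL), a step of a 1.4-fold higher number from compound 1 to compound 3 (0.15 log units; within the scatter) expected to be small.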

Compound 3, concentration for half-maximal effect: 7.8 ug/mL
The estimate for compound 3 lay 1.0-fold (0.01 log units) above the measured number; the range from low to high includes it.
By their numbers in this assay, from the lowest: compounds 2, 1 and 3 (each within the scatter of the next, the first and the last beyond it).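

At the saturated chain carbon bound to a double-bonded chain carbon, replacing the five-membered ring of the core of compound 1 with hydroxy(methoxycarbonyl)methyl gives a 1.4-fold higher number from compound 1 to compound 3 (0.14 log units; within the scatter) in this assay and so stays within the scatter. The intact ring is thus not required at this place for a number in this range, which the earlier step, confined to the other end of the chain, could not show. No measurement available here accounts for this result. From the compounds shown here alone, it remains open whether a carboxylic acid in place of the methoxycarbonyl group, or an amine in place of the hydroxy group, would leave the number in this range.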